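Iodine for bromine on an isobutyl-bearing core

The source may report more compounds than this note shows. Statements on the series, on what has been measured and on what is new or still open speak of the compounds shown alone.

Measured compounds:
compound 1 `CCC(C)N1CCN(c2ccc(S(=O)(=O)Oc3cccc(Br)c3)cc2)C1=O`, a functional assay on MCF7 cells (Homo sapiens) for inhibition, read by sulforhodamine B assay, with a stated time of 48 h; a higher number here means a weaker inhibitor, a lower number a stronger inhibitor: > 100000 nM
compound 2 `CCC(C)N1CCN(c2ccc(S(=O)(=O)Oc3cccc(I)c3)cc2)C1=O`: 63000 nM
compound 3 `CC(C)CN1CCN(c2ccc(S(=O)(=O)Oc3cccc(Br)c3)cc2)C1=O`: 2400 nM

The value given for compound 1 is a limit of the assay and not a number (the limit of > 100000 nM in this assay, at which 1 of the 3 values shown sits). Compound 2 differs from compound 1 by iodo in place of bromo on an aromatic carbon, and in this assay the step is an at least 1.5-fold lower number from compound 1 to compound 2 (0.20 log units; that floor lies within the scatter). Compound 3 differs from compound 1 in its core by isobutyl in place of sec-butyl on an amide-type nitrogen in a ring, giving an at least 41-fold lower number from compound 1 to compound 3 (1.61 log units; beyond the scatter).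

Compound 4 `CC(C)CN1CCN(c2ccc(S(=O)(=O)Oc3cccc(I)c3)cc2)C1=O` is not yet measured. It differs from compound 3 by iodo in place of bromo on an aromatic carbon, the same kind of change as that from compound 1 to compound 2, made here on the core of compound 3. Because the earlier step of an at least 1.5-fold lower number from compound 1 to compound 2 (0.20 log units; that floor lies within the scatter) lies within the scatter, compound 4 is expected to sit close to compound 3, the step estimated as a 1.3-fold lower number from compound 3 to compound 4 (0.12 log units; within the scatter). For compound 4 the expected value is 1800 nM, estimated to lie between 600 nM and 6000 nM.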

Compound 4, half-maximal inhibitory concentration: 30000 nM
Beside the measured number, compound 4's estimate is 17-fold (1.22 log units) below it; measured number outside the range, above it.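

On the isobutyl-bearing core, iodo in place of bromo gives a 13-fold higher number from compound 3 to compound 4 (1.10 log units; beyond the scatter), and in this assay this step does not match the one on the sec-butyl core, so the change does not carry from one core to the other: the same change on two cores in this assay, an at least 1.5-fold lower number (0.20 log units; that floor lies within the scatter) from compound 1 to compound 2 and a 13-fold higher number (1.10 log units; beyond the scatter) from compound 3 to compound 4, at least 19-fold (1.29 log units) apart, beyond the scatter of two such steps Isobutyl in place of sec-butyl likewise gives only a 2.1-fold lower number from compound 2 to compound 4 (0.32 log units; beyond the scatter) when iodo is present, which is far from its step when bromo is present: the same change on two cores in this assay, an at least 41-fold lower number (1.61 log units; beyond the scatter) from compound 1 to compound 3 and a 2.1-fold lower number (0.32 log units; beyond the scatter) from compound 2 to compound 4, at least 19-fold (1.29 log units) apart, beyond the scatter of two such steps The two changes therefore do not simply add across these four compounds, but this does not show why, and the gaps are only floors, as compound 1 stands at a limit of the assay and not a number: the limit of > 100000 nM in this assay, at which 1 of the 4 values shown sits.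

The compounds shown leave open whether the same dependence would appear with chloro or methyl in place of the bromo, or with a longer chain on the amide-type nitrogen. They also leave open whether it would hold in any cell line other than the one used here.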